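Chloro position on the aryl thiourea of compound 1

A few compounds are considered here, and "the series" means these few. Any claim that something is new, unique, unknown or untested is made for them only; others in the source may bear on it.

For the measured compounds named here, compound 1 `CC1(C)CC(NC(=S)Nc2cccc(Cl)c2)c2cc(Br)ccc2O1` gives 7000 nM in a functional assay on B16-F10 cells (Mus musculus) for inhibition, read by MTT assay, with a stated time of 72 h (on this read-out higher numbers stand for weaker inhibition and lower numbers for stronger inhibition), one of only two numbers in hand. Compound 3 `CC1(C)CC(NC(=S)Nc2cccc([N+](=O)[O-])c2)c2cc(Br)ccc2O1` gives 5000 nM, and the step of a 1.4-fold lower number from compound 1 to compound 3 (0.15 log units; within the scatter) lies within the scatter, so the two compounds are not separable. Compound 2 `CC1(C)CC(NC(=O)Nc2cccc(Cl)c2)c2cc(Br)ccc2O1` has "not determined" (no result reported) and adds nothing to the comparison. Compound 4 `CC1(C)CC(NC(=S)Nc2ccccc2Cl)c2cc(Br)ccc2O1` differs from compound 1 only in 2-chlorophenyl in place of 3-chlorophenyl on an amide-type nitrogen. Going by the values given here, no measured step moves the chloro substituent around the aryl ring; the one measured step exchanges it for nitro and stays within the scatter. There is no basis for expecting a shift beyond the scatter, so the step of no change at the digits printed from compound 1 to compound 4 (within the scatter) is expected to be small. Compound 4 is estimated at 7000 nM, within a range from 3000 nM to 16000 nM.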

Compound 4, half-maximal inhibitory concentration: 17000 nM
Beside the measured number, compound 4's estimate is 2.4-fold (0.39 log units) below it; the measured number lies above the stated range.
By their numbers in this assay, from the lowest: compounds 3 and 1 (each within the scatter of the next); then compound 4.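

Within this assay the change from 3-chlorophenyl to 2-chlorophenyl gives a 2.4-fold higher number from compound 1 to compound 4 (0.39 log units; beyond the scatter) and this modest step is the first in the series to lie beyond the scatter. Compounds 1 and 4 hold the same atoms, joined differently, so where the chloro sits on this aryl thiourea does register in inhibition, and the change weakens it. No available evidence bears on why the number shifts.

Still open, as far as these compounds go, is how a methoxy or a carboxylic acid on this aryl ring would read. Also open, from the compounds shown here alone, is whether the same chloro move on a urea would give a similar step.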